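Extending the anilino series to a 2-bromophenyl amine

This account rests on a few compounds, and the source may have more. Where it says the series, first, only, none or still open, it means among the compounds named here.

Compound 1 `Fc1ccc(Nc2nc(-c3cccc(F)c3)nc3ccc(F)cc23)cc1` was assessed in a functional assay on U2OS cells (Homo sapiens) for cytotoxicity, read by MTT assay, with a stated time of 48 h; a higher number here means a weaker inhibitor, a lower number a stronger inhibitor. In this assay compound 1 gives > 50000 nM, which is a limit of the assay and not a number. Compound 2 `Fc1cccc(-c2nc(Nc3ccccc3Cl)c3cc(F)ccc3n2)c1` gives > 50000 nM in this assay, likewise only a limit. Compound 3 `Fc1cccc(-c2nc(Nc3ccc(Br)cc3)c3cc(F)ccc3n2)c1` gives > 50000 nM in this assay, again a limit. Accordingly (the limit of > 50000 nM in this assay, at which 3 of the 3 values shown sit). Among the compounds with values here, none of the measured steps can be sized: a step that the two limits leave unreadable from compound 1 to compound 2, a step that the two limits leave unreadable from compound 1 to compound 3 and a step that the two limits leave unreadable from compound 2 to compound 3.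

Compound 4 `Fc1cccc(-c2nc(Nc3ccccc3Br)c3cc(F)ccc3n2)c1` remains to be measured. It differs from compound 1 in 2-bromophenyl in place of 4-fluorophenyl on a nitrogen on an aromatic ring. The two measured changes of the aryl group on that nitrogen, from compound 1 to compound 2 and from compound 1 to compound 3, both left the value outside the measurable range, so no readable step is available as a guide. In this assay the expected step is a step that the limit leaves unreadable from compound 1 to compound 4, that is, none beyond the scatter. Compound 4 is expected in this assay to give 80000 nM, with a range from 50000 nM to 200000 nM, and most probably to be reported again only as a limit.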

Compound 4, half-maximal inhibitory concentration: > 50000 nM
Compound 4: a limit, no number (the forecaster's own chance of this, stated with the estimate: 90%); the middle value is on the limit's open side.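

In this assay, within the data shown here, no step from compound 4 to compound 1, compound 2 or compound 3 can be read: the limit of > 50000 nM in this assay, at which 4 of the 4 values shown sit.

The compounds shown leave open whether any aryl group on that nitrogen, or any change elsewhere on the shared core, gives a measurable value instead of a limit.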